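The compounds below may be only part of what the source reports. "The series", "measured", "known", "first", "only" and "open" are said of these compounds alone.

Measured in this series:
compound 1 `CCN1CCN(CCCn2cnc3c(N4CCN(CC)CC4)ncnc32)CC1` — 1190 nM
compound 2 `CCN1CCN(c2nc(NCc3ccc(CN(C)C)cc3)nc3c2ncn3CCCN2CCCC2)CC1` — 90 nM

In an assay on HEK293 cells for antagonist activity at Toll-like receptor 9 (Homo sapiens), read by spectrophotometry (on this read-out lower numbers stand for stronger inhibition and higher numbers for weaker inhibition), compound 1 gives 1190 nM, the higher of the two numbers; compound 2 gives 90 nM, and the gap between the two lies beyond the scatter. Within the data shown here, no step between measured compounds differing in one place is available. Compound 3 `CCN1CCN(CCCn2cnc3c(N4CCN(CC)CC4)nc(NCc4ccc(F)cc4)nc32)CC1` is compound 1 with (4-fluorobenzyl)amino in place of hydrogen on an aromatic carbon. Because compound 2, which also carries a substituent of the benzylamino kind, gives 90 nM, a downward step beyond the scatter is expected, estimated as a 5.4-fold lower number from compound 1 to compound 3 (0.73 log units; beyond the scatter). For compound 3 the estimate is 220 nM, within 60 nM to 700 nM.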

Compound 3, half-maximal inhibitory concentration: 470 nM
Compound 3: middle estimate off by 2.1-fold (0.33 log units), on the low side; the range from low to high includes it.
By their numbers in this assay, from the lowest: compound 2; then compound 3; then compound 1.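

In this assay, the aromatic carbon between two ring nitrogen atoms accepts a substituent without loss of inhibition: (4-fluorobenzyl)amino in place of hydrogen gives a 2.5-fold lower number from compound 1 to compound 3 (0.40 log units; beyond the scatter) as a modest gain. Among these compounds, this is the first one-place reading at this position, and its direction is downward. Nothing measured here accounts for the step.

Open, going by these compounds, is whether the fluorine contributes, which a plain benzylamino group would test. Also open, on these data alone, is how a smaller amine such as methylamino, or a carboxylic acid on the benzyl ring, would read at this carbon.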